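Replacing 4-chlorophenyl with pyridin-4-yl: an expected stability

The compounds below may be only part of what the source reports. "The series", "measured", "known", "first", "only" and "open" are said of these compounds alone.

Measured so far in an ADME assay on S9 fraction from liver (Rattus norvegicus) for metabolic stability, read by LC-MS, using NADPH, with a stated time of 30 min; a higher number here means that more of the compound is left, a lower number that less of the compound is left 

Compound 1 (`CCCCCCCCc1ccc(OCC(=O)Cn2ncnn2)cc1`) gives < 5% 
Compound 2 (`CCCCCCCCc1ccc(OCC(=O)Cn2cnnn2)cc1`) gives 22% 
Compound 3 (`CCCCCCCCc1ccc(OCC(=O)Cn2nnc(-c3ccc(Cl)cc3)n2)cc1`) gives 74% 

The value of compound 1 (< 5%) is a limit of the assay and not a number. Compound 3 stands highest at 74%, and compound 2 reaches 22%, with the gap beyond the scatter.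

In compound 4 (`CCCCCCCCc1ccc(OCC(=O)Cn2nnc(-c3ccncc3)n2)cc1`), pyridin-4-yl takes the place of 4-chlorophenyl on an aromatic carbon (pyridin-4-yl in place of 4-chlorophenyl on an aromatic carbon).

Going by the values given here, two measured steps bear on this change. The closer one puts 4-chlorophenyl in place of hydrogen at this same place, a number at least 69 percentage points higher from compound 1 to compound 3 (beyond the scatter), and compound 4 keeps a six-membered aromatic ring there, so much of that large gain is expected to remain. The other, a number at least 17 percentage points higher from compound 1 to compound 2 (beyond the scatter), exchanges 2H-tetrazol-2-yl for 1H-tetrazol-1-yl and bears only loosely. Both start from a limit (the limit of < 5% in this assay, at which 1 of the 3 values shown sits) and so give only a minimum size. Among the compounds with values here, no measured pair exchanges one ring for another at this place, so the uncertainty is wide.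

The expected step is a moderate fall, a number 19 percentage points lower from compound 3 to compound 4 (beyond the scatter), in this assay. For compound 4 the estimate is 55%, with an expected range from 25% to 85%.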

Compound 4, percent of the compound remaining: < 5%
Compound 4: only a limit was reported (the forecaster's own chance of this, stated with the estimate: 3%); at least 50 percentage points between middle value and limit.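

The earlier compounds shown here showed only that 4-chlorophenyl at this place goes with far more compound left than hydrogen, and they could not tell whether any six-membered aromatic ring would serve. In this assay, pyridin-4-yl does not serve in the same way, with a number at least 69 percentage points lower from compound 3 to compound 4 (beyond the scatter). Compound 4 gives a limit of the assay and not a number, as does compound 1, so the step between these two cannot be read: the limit of < 5% in this assay, at which 2 of the 4 values shown sit.

The change from 4-chlorophenyl to pyridin-4-yl removes the chlorine and brings a nitrogen into the ring in one step, so the compounds shown cannot say which of the two matters. As far as these compounds go, how a plain phenyl or a pyridin-3-yl would stand at this place remains open.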